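Furan-2-yl in place of 1H-pyrrol-2-yl: an expected step

The compounds below may be only part of what the source reports. "The series", "measured", "known", "first", "only" and "open" are said of these compounds alone.

Of the compounds shown here, three have been measured in a functional assay on HL-60 cells (Homo sapiens) for inhibition, read by MTT assay, with a stated time of 48 h; on this read-out lower numbers stand for stronger inhibition and higher numbers for weaker inhibition. Compound 1 `O=C(/C=C/c1cccc([N+](=O)[O-])c1)c1ccc[nH]1` gives 20000 nM. Compound 2 `O=C(/C=C/c1ccc(Cl)cc1)c1ccc[nH]1` gives 13000 nM in this assay, and compound 3 `O=C(/C=C/c1ccc(Cl)cc1)c1ccco1` gives 19000 nM. The change from compound 2 to compound 3 is furan-2-yl in place of 1H-pyrrol-2-yl on a carbonyl carbon, and it made a step of a 1.5-fold higher number from compound 2 to compound 3 (0.16 log units; within the scatter). The difference between the cores of compound 1 and compound 2 is not broken down here. Compound 4 `O=C(/C=C/c1cccc([N+](=O)[O-])c1)c1ccco1` has not been measured; it differs from compound 1 by furan-2-yl in place of 1H-pyrrol-2-yl on a carbonyl carbon, the same change at the same place, which occurs twice among these compounds. The step from compound 1 to compound 4 in this assay is expected to be a 1.5-fold higher number from compound 1 to compound 4 (0.18 log units; within the scatter), beside the earlier one, and it rests on compound 3 because 19000 nM was what the same change gave there. Compound 4 is therefore estimated at 30000 nM in this assay, expected to lie between 12000 nM and 75000 nM.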

Compound 4, half-maximal inhibitory concentration: 14000 nM
Beside the measured number, compound 4's estimate is 2.1-fold (0.33 log units) above it, and the stated range covers the measured number.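

In this assay, furan-2-yl in place of 1H-pyrrol-2-yl on a carbonyl carbon gave a 1.4-fold lower number from compound 1 to compound 4 (0.15 log units; within the scatter). Set beside the earlier step, the change has now been read on two cores, and the two steps do not differ: the same change on two cores in this assay, a 1.5-fold higher number (0.16 log units; within the scatter) from compound 2 to compound 3 and a 1.4-fold lower number (0.15 log units; within the scatter) from compound 1 to compound 4, 2.1-fold (0.32 log units) apart, within the scatter of two such steps. This shows that on these two cores the change stays within the scatter, but it gives the change no reliable direction and does not show that the same would hold on any further core.

The compounds shown leave open whether the change stays this small on a core carrying an amine or a carboxylic acid. They also leave open what a longer chain would give in place of either five-membered ring.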